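The source may report more compounds than this note shows. Statements on the series, on what has been measured and on what is new or still open speak of the compounds shown alone.

Measured so far in a functional assay on KYSE-450 cells (Homo sapiens) for inhibition, read by MTT assay, with a stated time of 48 h; a higher number here means a weaker inhibitor, a lower number a stronger inhibitor
Compound 1 `COCC(=O)N(Cc1ccc(OC)c(O)c1)c1cc(OC)c(OC)c(OC)c1` gives 460 nM
Compound 2 `COc1ccc(CN(C(=O)/C=C/CBr)c2cc(OC)c(OC)c(OC)c2)cc1O` gives 100 nM

Compound 2 at 100 nM holds the lower of the two numbers, which makes it the stronger inhibitor of this pair. The next compound, compound 3 `COc1ccc(CN(C(=O)C[Se]C#N)c2cc(OC)c(OC)c(OC)c2)cc1O`, keeps the shared core and changes only the group on the carbonyl carbon: a group of 4 heavy atoms (2 carbon, 1 nitrogen, 1 selenium; no ring) in place of a group of 4 heavy atoms (3 carbon, 1 bromine; no ring), on a carbonyl carbon. Among the compounds with values here, the entering group has no common name, and no measured compound carries it.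

Within the data shown here, only one measured step bears on this change. That step, a 4.6-fold lower number from compound 1 to compound 2 (0.66 log units; beyond the scatter), was made at the same place and is modest in size. It shows that the number in this assay can respond to a swap on this carbonyl carbon, but it gives no direction for a group not yet tested. A move of similar size either way would therefore not be surprising, and the central expectation is a small one. The estimated change a 1.3-fold lower number from compound 2 to compound 3 (0.10 log units; within the scatter) is expected to stay within the scatter. Compound 3 is expected at 80 nM with an estimated range from 20 nM to 320 nM on this read-out.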

Compound 3, half-maximal inhibitory concentration: 280 nM
For compound 3 the middle estimate is 3.5-fold (0.54 log units) below the measured one, within the range that was stated.
By their numbers in this assay, from the lowest: compound 2; then compounds 3 and 1 (each within the scatter of the next).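

In this assay, exchanging 3-bromoprop-1-en-1-yl for the selenium-bearing nitrile group gave a 2.8-fold higher number from compound 2 to compound 3 (0.45 log units; beyond the scatter), which shows that the number on this carbonyl carbon can also rise, even between groups that each count 4 heavy atoms and carry no ring. The comparison with the methoxymethyl compound gave a 1.6-fold lower number from compound 1 to compound 3 (0.22 log units; within the scatter), so compound 3 cannot be told apart from compound 1 in this assay, and the selenium-bearing group does not repeat the fall seen in a 4.6-fold lower number from compound 1 to compound 2 (0.66 log units; beyond the scatter). Among the three groups, only 3-bromoprop-1-en-1-yl stands apart, and compound 2 is the strongest of the set, with its steps to both others beyond the scatter.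

As far as these compounds go, it remains open whether the lower number of compound 2 depends on the bromine or on the double bond, and how a plain propenyl chain, a chloroacetyl group or the sulfur counterpart of the selenium-bearing nitrile group would compare at this place. Nothing available explains the difference between these groups.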